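Methoxy for Fluoro: An Estimate of Anticonvulsant Dose

The source may hold more compounds than are shown below. What is called first, only, known or untested is meant among the compounds shown, and "the series" means these compounds.

Compound 1 `O=C(Nc1nc2ccc(Cl)cc2s1)c1ccccc1C(=O)c1ccccc1` and compound 2 `O=C(Nc1nc2ccc(F)cc2s1)c1ccccc1C(=O)c1ccccc1` share one core and differ at a single aromatic carbon. In a functional assay on the whole organism with Mus musculus as the target, in the maximal electroshock model, with a stated time of 4 h (a higher number here means that more compound is needed for the effect, a lower number that less compound is needed), compound 1 gives 100 mg/kg, and compound 2 gives 100 mg/kg; the step of no change at the digits printed from compound 1 to compound 2 (within the scatter) shows that fluoro in place of chloro is followed by no shift in the dose. Compound 3 `COc1ccc2nc(NC(=O)c3ccccc3C(=O)c3ccccc3)sc2c1` carries methoxy in place of fluoro on an aromatic carbon. Going by the values given here, no measured step exchanges a halogen for methoxy, so only the halogen swap bears on this change, and it was flat. Compound 3 is therefore expected to stay level, no change at the digits printed from compound 2 to compound 3 (within the scatter), at an estimated 100 mg/kg with a range from 50 mg/kg to 300 mg/kg.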

Compound 3, minimum effective dose: 100 mg/kg
Compound 3: middle estimate and measured number agree at the digits printed, and the stated range covers the measured number.
By their numbers in this assay, from the lowest: compounds 1, 2 and 3 (each within the scatter of the next).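

In this assay, methoxy in place of fluoro gives no change at the digits printed from compound 2 to compound 3 (within the scatter) and methoxy in place of chloro gives no change at the digits printed from compound 1 to compound 3 (within the scatter). The earlier compounds had shown only one halogen exchanged for another, whereas this aromatic carbon now also carries a group that enters with oxygen and a hydrogen-bond acceptor, with no shift in the dose. No measurement at hand explains this flat result. On these data alone, whether an amine, a carboxylic acid or a longer chain at this carbon would shift the dose remains open. So does the effect of changes elsewhere on the shared core.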